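This account rests on a few compounds, and the source may have more. Where it says the series, first, only, none or still open, it means among the compounds named here.

Compound 2 `Fc1ccc(Cc2ccc3c(NCCCNCc4ccco4)ccnc3c2)cc1` is one of two measured members of this series; the other is compound 1 `COc1ccc(F)cc1CNCCCNc1ccnc2cc(C3CCCCC3)ccc12`. In an ADME assay for permeability, using PAMPA, with a stated time of 30 min, at pH 7.4 (a higher number here means that the compound crosses the layer faster, a lower number that the compound crosses the layer more slowly), compound 1 gives 23 10^-6 cm/s. In this assay compound 2 gives 23 10^-6 cm/s, level with compound 1 at the digits shown and within the scatter of it.

Compound 3 `c1coc(CNCCCNc2ccnc3cc(C4CCCCC4)ccc23)c1` has not yet been measured in this assay. It differs from compound 2 in one place: cyclohexyl in place of 4-fluorobenzyl on an aromatic carbon. The cyclohexyl that enters is the same group that compound 1 carries on its core, while the remainder of compound 3 matches compound 2. Since compound 1 and compound 2 stand at the same value in this assay, no step beyond the scatter is expected from compound 2 to compound 3; the estimated step is a 1.0-fold lower number from compound 2 to compound 3 (0.02 log units; within the scatter). For compound 3 the expected value in this assay is 22 10^-6 cm/s, with a range from 11 10^-6 cm/s to 40 10^-6 cm/s.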

Compound 3, apparent permeability: 23 10^-6 cm/s
Compound 3: the middle estimate sits 1.0-fold (0.02 log units) below what was measured, within the range that was stated.
By their numbers in this assay, from the lowest: compounds 1, 2 and 3 (each within the scatter of the next).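

In this assay, placing cyclohexyl instead of 4-fluorobenzyl on the aromatic carbon gives no change at the digits printed from compound 2 to compound 3 (within the scatter), so a non-aromatic carbon ring of 6 heavy atoms and an aromatic-ring group of 8 heavy atoms with one fluorine read alike at this position. The change at the other end of the molecule, furan-2-yl in place of 5-fluoro-2-methoxyphenyl on the saturated chain carbon bound to an amine nitrogen, gives no change at the digits printed from compound 1 to compound 3 (within the scatter), so neither single change shifts the read-out beyond the scatter. Nothing available explains this lack of movement.

Going by these compounds, all three compounds share one value, so it remains unknown how far this read-out can move. A carboxylic acid or an amine on that aromatic carbon, or a longer chain in place of the linker, could still give a different number.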